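The compounds below may be only part of what the source reports. "The series", "measured", "known", "first", "only" and "open" are said of these compounds alone.

Of the compounds shown here, two have been measured in an assay on isolated protein for inhibition of retinal dehydrogenase 2 (Homo sapiens); a higher number here means a weaker inhibitor, a lower number a stronger inhibitor.
Compound 1, `Cn1ccc2c(=O)n(-c3ccccc3)c(SCc3cccc(F)c3)nc21`, gives 810 nM.
Compound 2, `CC(Sc1nc2nn(C3COC3)cc2c(=O)n1-c1ccccc1)c1ccccn1`, gives 21 nM.

Compound 2 has the lower of the two numbers in this assay, and its gap from compound 1 lies beyond the usual scatter, so compound 2 is the stronger inhibitor of the pair. Compound 3, `CC(Sc1nc2nn(C3COC3)cc2c(=O)n1-c1ccccc1)c1cccnc1`, has not yet been measured. It keeps every atom of compound 2 but joins them differently: pyridin-3-yl in place of pyridin-2-yl on a saturated chain carbon bound to a saturated chain carbon and a sulfur. Nothing in the two measured compounds shows what swapping one pyridinyl for the other does, since compound 1 differs from compound 2 in several places at once. The expectation is therefore a modest step, if any, in this assay, most likely toward a somewhat higher number, estimated as a 2.1-fold higher number from compound 2 to compound 3 (0.33 log units; beyond the scatter). On that basis compound 3 is expected to give about 45 nM, within a range from 12 nM to 200 nM.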

Compound 3, half-maximal inhibitory concentration in the retinal dehydrogenase 2 assay: 58 nM
For compound 3 the middle estimate is 1.3-fold (0.11 log units) below the measured one; the measured number falls inside the stated range.
By their numbers in the retinal dehydrogenase 2 assay, from the lowest: compound 2; then compound 3; then compound 1.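

Moving from pyridin-2-yl to pyridin-3-yl on this saturated chain carbon adds and removes no atoms, yet in the retinal dehydrogenase 2 assay it gives a 2.8-fold higher number from compound 2 to compound 3 (0.44 log units; beyond the scatter), so the two pyridinyl forms are not interchangeable here and compound 2 is the stronger inhibitor of the pair. The same swap gives up that inhibition while raising the number in a physicochemical assay for solubility, using the shake flask method, in phosphate buffer, with a stated time of 24 h, at pH 7.4 (a higher number here means a more soluble compound, a lower number a less soluble compound), which makes compound 3 the more soluble of the two: the measured solubility of compound 2, 60000 nM, and of compound 3, 189000 nM, a 3.2-fold higher number (0.50 log units; beyond the scatter) In the physicochemical assay compound 2 gives 60000 nM and compound 3 gives 189000 nM as measured. Compound 1 differs from compound 2 in several places at once, so neither shift could be read from it.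

As far as these compounds go, it remains open whether pyridin-4-yl or a plain phenyl ring at this place would combine the stronger inhibition of compound 2 with the higher solubility of compound 3. From the compounds shown here alone, it is also open whether the same swap would have a similar effect on a different core.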